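The source may report more compounds than this note shows. Statements on the series, on what has been measured and on what is new or still open speak of the compounds shown alone.

Compound 1, `C=C(c1ccc(OC)cc1NC(=O)CO)c1ccc(OC)c2c1OC(C)(C)C=C2`, is the starting point. In a functional assay on A2780 cells (Homo sapiens) for antiproliferative activity, read by MTT assay, with a stated time of 48 h (a lower number here means a stronger inhibitor, a higher number a weaker inhibitor), compound 1 gives 40 nM. Compound 3, `C=C(c1ccc(OC)cc1NC(=O)CN)c1ccc(OC)c2c1OC(C)(C)C=C2`, carries a single change from it, (amino in place of hydroxy on a saturated chain carbon bound to a carbonyl carbon). In this assay compound 3 gives 80 nM, and the step is a 2.0-fold higher number from compound 1 to compound 3 (0.30 log units; within the scatter). Compound 2, `C=C(c1ccc2c(c1)C=CC(C)(C)O2)c1ccc(OC)cc1NC(=O)CO`, is built on a different core; how the two cores differ is not broken down here. In this assay compound 2 gives 110 nM, a higher number than compound 1 shows. Compound 4, `C=C(c1ccc2c(c1)C=CC(C)(C)O2)c1ccc(OC)cc1NC(=O)CN`, has not yet been measured. It differs from compound 2 by amino in place of hydroxy on a saturated chain carbon bound to a carbonyl carbon, the same change at the same place as before. Among the compounds with values here, the step of a 2.0-fold higher number from compound 2 to compound 4 (0.30 log units; within the scatter) is expected to be small, because the one measured example of this change is a 2.0-fold higher number from compound 1 to compound 3 (0.30 log units; within the scatter). Accordingly compound 4 is estimated at 220 nM, with a likely range from 110 nM to 450 nM.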

Compound 4, half-maximal inhibitory concentration: 140 nM
The estimate for compound 4 lay 1.6-fold (0.20 log units) above the measured number; measured number inside the range.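

In this assay, amino in place of hydroxy now gives a 1.3-fold higher number from compound 2 to compound 4 (0.10 log units; within the scatter). Set beside the earlier step, the change carries over from one core to the other with no difference that can be told apart: the same change on two cores in this assay, a 2.0-fold higher number (0.30 log units; within the scatter) from compound 1 to compound 3 and a 1.3-fold higher number (0.10 log units; within the scatter) from compound 2 to compound 4, 1.6-fold (0.20 log units) apart, within the scatter of two such steps. This shows that on these two cores the swap stays within the scatter, but two cores say nothing about any other core, and steps this small cannot show that amino and hydroxy truly differ here.

The compounds shown leave open what other groups would do on this saturated chain carbon bound to a carbonyl carbon, such as a dimethylamino group, a carboxylic acid or a longer chain. On these data alone, whether the same holds on a third core also stays open.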